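A few compounds are considered here, and "the series" means these few. Any claim that something is new, unique, unknown or untested is made for them only; others in the source may bear on it.

Compound 3 `O=[N+]([O-])c1ccc(CN2CCC(n3cc(CC(OCc4cc(-c5ccccc5Br)no4)c4ccc(Br)cc4)nn3)CC2)cc1` stands in a functional assay on Caco-2 cells (Homo sapiens) for cytotoxicity, with a stated time of 48 h (on this read-out higher numbers stand for weaker inhibition and lower numbers for stronger inhibition), at 3000 nM, level with compound 2 `N#Cc1cccc(-c2cc(COC(Cc3cn(C4CCN(Cc5ccc([N+](=O)[O-])cc5)CC4)nn3)c3ccc(Br)cc3)on2)c1`, which gives 3000 nM, the two together forming the lowest of the three numbers; compound 1 `O=[N+]([O-])c1ccc(CN2CCC(n3cc(CC(OCc4cc(-c5cccc(Br)c5)no4)c4ccc(Br)cc4)nn3)CC2)cc1` gives 5000 nM. For the measured compounds named here, none of the measured steps leaves the scatter: a 1.7-fold lower number from compound 1 to compound 2 (0.22 log units; within the scatter), a 1.7-fold lower number from compound 1 to compound 3 (0.22 log units; within the scatter) and no change at the digits printed from compound 2 to compound 3 (within the scatter). Compound 4 `COc1ccccc1-c1cc(COC(Cc2cn(C3CCN(Cc4ccc([N+](=O)[O-])cc4)CC3)nn2)c2ccc(Br)cc2)on1` differs from compound 3 by methoxy in place of bromo on an aromatic carbon. The two steps leading into compound 3 both altered the group on this same ring, so a similar outcome is expected here, and the step is estimated as no change at the digits printed from compound 3 to compound 4 (within the scatter) because a 1.7-fold lower number from compound 1 to compound 3 (0.22 log units; within the scatter) and no change at the digits printed from compound 2 to compound 3 (within the scatter) stayed within the scatter. Compound 4 is accordingly expected to give 3000 nM in this assay, within a range from 1500 nM to 7000 nM.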

Compound 4, half-maximal inhibitory concentration: > 25000 nM
Compound 4 gave a limit, no number; the forecaster's own chance of this, stated with the estimate: 10%; middle value at least 8.3-fold (0.92 log units) from the limit.
By their numbers in this assay, from the lowest: compounds 2, 3 and 1 (each within the scatter of the next). At a limit, above all of these: compound 4.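

In this assay the reading for compound 4 is a limit of the assay and not a number: the limit of > 25000 nM in this assay, at which 1 of the 4 values shown sits. The earlier changes on this ring all stayed within the scatter, whereas methoxy in place of bromo leaves it, toward weaker inhibition, with an at least 8.3-fold higher number from compound 3 to compound 4 (0.92 log units; beyond the scatter). The other two steps into compound 4 point the same way, with an at least 8.3-fold higher number from compound 2 to compound 4 (0.92 log units; beyond the scatter) and an at least 5.0-fold higher number from compound 1 to compound 4 (0.69 log units; beyond the scatter), so this ring position is not indifferent to the group it carries. As far as these compounds go, whether a hydroxyl or a methyl in this place, ortho to a large group, would read like bromo or like methoxy stays open. Also open, from the compounds shown here alone, is how far the number for compound 4 lies beyond its limit.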